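Lactam ring swap on the amide nitrogen of compound 3

This account rests on a few compounds, and the source may have more. Where it says the series, first, only, none or still open, it means among the compounds named here.

Measured compounds in an assay for inhibition of 6-phosphofructo-2-kinase/fructose-2,6-bisphosphatase 3 (Homo sapiens), read by ADP-Glo, with a stated time of 2 h; on this read-out higher numbers stand for weaker inhibition and lower numbers for stronger inhibition:
compound 1, `CN1CCC(NC(=O)c2ccncc2Nc2cc(-c3ccc4ccn(C)c4c3)c3nccnc3c2)CC1`, 38 nM
compound 2, `Cn1ccc2ccc(-c3cc(Nc4cnccc4C(=O)NC4CCNC(=O)C4)cc4nccnc34)cc21`, 69 nM
compound 3, `CC(=O)N1CCCC(NC(=O)c2ccncc2Nc2cc(-c3ccc4ccn(C)c4c3)c3nccnc3c2)C1`, 11 nM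

Compound 3 holds the lowest number of the three in this assay. Its advantage over compound 1 is a 3.5-fold lower number from compound 1 to compound 3 (0.54 log units; beyond the scatter) and over compound 2 it is a 6.3-fold lower number from compound 2 to compound 3 (0.80 log units; beyond the scatter), both beyond the scatter, whereas the gap between compound 1 and compound 2, a 1.8-fold higher number from compound 1 to compound 2 (0.26 log units; within the scatter), is not. Compound 4, `CN1CC(NC(=O)c2ccncc2Nc2cc(-c3ccc4ccn(C)c4c3)c3nccnc3c2)CCC1=O`, has not yet been measured. The change from compound 3 to compound 4 is 1-methyl-6-oxopiperidin-3-yl in place of 1-acetylpiperidin-3-yl on an amide-type nitrogen. The step that bears on it most directly is that from compound 2 to compound 3, where a ring carrying a ring carbonyl was replaced by the 1-acetylpiperidin-3-yl group and the number fell; compound 4 returns a ring carbonyl, now within 1-methyl-6-oxopiperidin-3-yl, so the reverse direction seems plausible. Compound 4 is therefore expected to show a modest rise in this assay, estimated as a 2.7-fold higher number from compound 3 to compound 4 (0.44 log units; beyond the scatter), smaller than the whole of that earlier step because compound 2 gives 69 nM while carrying 2-oxopiperidin-4-yl, which is not the same group as the 1-methyl-6-oxopiperidin-3-yl of compound 4. The estimate for compound 4 is 30 nM, with a range from 12 nM to 80 nM.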

Compound 4, half-maximal inhibitory concentration: 116 nM
For compound 4 the middle estimate is 3.9-fold (0.59 log units) below the measured one; the measured number lies above the stated range.
By their numbers in this assay, from the lowest: compound 3; then compounds 1, 2 and 4 (each within the scatter of the next, the first and the last beyond it).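

In this assay the swap of 1-acetylpiperidin-3-yl for 1-methyl-6-oxopiperidin-3-yl gives an 11-fold higher number from compound 3 to compound 4 (1.02 log units; beyond the scatter) even though the ring size and the counts of donors and acceptors stay the same, so at this amide-type nitrogen the result depends on more than those counts and on the presence of a carbonyl in the group. Compound 4 stays close to the other ring-carbonyl compound, with a 1.7-fold higher number from compound 2 to compound 4 (0.23 log units; within the scatter) and no order to be drawn between them, while the carbonyl-free 1-methylpiperidin-4-yl group of compound 1 gives the lower number in a 3.1-fold higher number from compound 1 to compound 4 (0.48 log units; beyond the scatter) and so goes against any simple rule that a carbonyl-free ring sits level with the lactams, just as its within-scatter gap to compound 2 goes against any rule that it always does better. Nothing available here explains why these groups differ.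

The compounds shown leave open whether the low number of compound 3 goes with the acetyl on the ring nitrogen or with the piperidin-3-yl attachment. A 1-acetylpiperidin-4-yl group would separate those two, and a 1-methanesulfonylpiperidin-3-yl group would show whether the acetyl can be replaced at all.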